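The source may hold more compounds than are shown below. What is called first, only, known or untested is meant among the compounds shown, and "the series" means these compounds.

Working notes on the series. Compound 1 `COc1ccc(/C=C\c2cc(OC)c(OC)c(OC)c2)cc1OCc1ccc(CNCCO)cc1` is the reference point here. Within the data shown here, in a functional assay on HeLa cells (Homo sapiens) for antiproliferative activity, read by CCK-8 assay, with a stated time of 48 h (on this read-out higher numbers stand for weaker inhibition and lower numbers for stronger inhibition), compound 1 gives 4400 nM, the lowest of the three numbers measured so far. Compound 2 `COc1ccc(/C=C\c2cc(OC)c(OC)c(OC)c2)cc1OCc1ccc(CN2CC[C@@H](C(=O)O)C2)cc1` gives 12800 nM in this assay, and compound 3 `COc1ccc(/C=C\c2cc(OC)c(OC)c(OC)c2)cc1OCc1ccc(CN2CCCCC2C(=O)NCCN)cc1` gives 7300 nM in this assay. The step of a 2.9-fold higher number from compound 1 to compound 2 (0.46 log units; beyond the scatter) is the only one beyond the scatter; the step of a 1.7-fold higher number from compound 1 to compound 3 (0.22 log units; within the scatter) and the step of a 1.8-fold lower number from compound 2 to compound 3 (0.24 log units; within the scatter) both stay inside it.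

Compound 4 `COc1ccc(/C=C\c2cc(OC)c(OC)c(OC)c2)cc1OCc1ccc(CN[C@H](C(=O)O)[C@@H](C)O)cc1` is not yet measured in this assay. Against compound 1 the change is 1-carboxy-2-hydroxypropyl in place of 2-hydroxyethyl on an amine nitrogen. Both measured steps from compound 1 also replace the (2-hydroxyethyl)amino group, but each with a ring amine; compound 4 instead keeps an open-chain substituent on the amine nitrogen, now carrying a carboxy and a hydroxy group. Among the measured compounds shown here, the nearest precedent for adding a carboxy group is a 2.9-fold higher number from compound 1 to compound 2 (0.46 log units; beyond the scatter), a modest rise; the precedent for a larger substituent with extra donors is a 1.7-fold higher number from compound 1 to compound 3 (0.22 log units; within the scatter), within the scatter. On that basis the expected step of a 1.5-fold higher number from compound 1 to compound 4 (0.17 log units; within the scatter) is a small rise or none beyond the scatter. Compound 4 is therefore estimated at 6500 nM in this assay, with a range from 3000 nM to 14000 nM.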

Compound 4, half-maximal inhibitory concentration: > 10000 nM
Compound 4 was reported as a limit (the forecaster's own chance of this, stated with the estimate: 5%); middle value at least 1.5-fold (0.18 log units) from the limit.
By their numbers in this assay, from the lowest: compounds 1, 3 and 2 (each within the scatter of the next, the first and the last beyond it).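

Compound 4 is the only compound here with a limit rather than a number for its read-out in this assay: the limit of > 10000 nM in this assay, at which 1 of the 4 values shown sits.

On the amine nitrogen, 1-carboxy-2-hydroxypropyl in place of 2-hydroxyethyl keeps an open chain with no ring and still gives an at least 2.2-fold higher number from compound 1 to compound 4 (0.35 log units; beyond the scatter); a step beyond the scatter therefore appears with a carboxy group on an open chain as well as on the ring amine of compound 2, while compound 3, which carries no carboxy group, stays within the scatter of compound 1. Against the other replacement, the step reads an at least 1.3-fold higher number from compound 3 to compound 4 (0.13 log units; that floor lies within the scatter), so no order can be set between those two compounds, and the step from compound 2 to compound 4 cannot be read.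

As far as these compounds go, compound 4 brings in the carboxy and the extra hydroxy group together, so the share of each in the step stays open; a 1-carboxyethyl group on the same nitrogen, or a methyl ester in place of the carboxylic acid, would bear on this. From the compounds shown here alone, what the two defined stereocentres of compound 4 contribute also stays open.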